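A few compounds are considered here, and "the series" means these few. Any claim that something is new, unique, unknown or untested is made for them only; others in the source may bear on it.

Measured in an ADME assay (liver) for pharmacokinetics, with Liver microsome (Rattus norvegicus) as the target, using microsomes; on this read-out lower numbers stand for a shorter-lived compound and higher numbers for a longer-lived compound:
- compound 1, `CCOc1cc(NC(=O)C2(NC(=O)c3ccc4c(C5CCCC5)c(-c5ncc(Cl)cn5)n(C)c4c3)CCC2)ccc1/C=C/C(=O)OC(=O)C[C@H](O)C(=O)O`: 7.92 h
- compound 2, `CCOc1cc(NC(=O)C2(NC(=O)c3ccc4c(C5CCCC5)c(-c5ncc(Cl)cn5)n(C)c4c3)CCC2)ccc1/C=C/C(=O)OCC(C)C`: 1.42 h
- compound 3, `CCOc1cc(NC(=O)C2(NC(=O)c3ccc4c(C5CCCC5)c(-c5ncc(Cl)cn5)n(C)c4c3)CCC2)ccc1/C=C/C(=O)OCCOc1ccccc1`: 16.5 h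

Compound 3 stands highest of the three in this assay; compound 1 is nearest (a 2.1-fold higher number from compound 1 to compound 3 (0.32 log units; beyond the scatter)) and compound 2 furthest (a 12-fold higher number from compound 2 to compound 3 (1.07 log units; beyond the scatter)). Compound 4, `CCOc1cc(NC(=O)C2(NC(=O)c3ccc4c(C5CCCC5)c(-c5ncc(Cl)cn5)n(C)c4c3)CCC2)ccc1/C=C/C(=O)OCC(=O)N(C)C(C)C`, has not yet been measured. Its difference from compound 3 is isopropyl(methyl)carbamoyl in place of phenoxymethyl on a saturated chain carbon bound to an oxygen next to a carbonyl group.

Going by the values given here, no measured step has the same entering group. The step that bears most on it is the one at the same place, a 12-fold higher number from compound 2 to compound 3 (1.07 log units; beyond the scatter), which shows that what sits on this saturated chain carbon moves the read-out by a large amount in this series. The two steps from compound 1, a 5.6-fold lower number from compound 1 to compound 2 (0.75 log units; beyond the scatter) and a 2.1-fold higher number from compound 1 to compound 3 (0.32 log units; beyond the scatter), also show the whole ester side as a sensitive position. Removing the phenoxymethyl that accompanies the highest number is therefore expected to lower the read-out, by a modest step rather than the large one seen from compound 2. The expected step is a 3.3-fold lower number from compound 3 to compound 4 (0.52 log units; beyond the scatter), and the estimate for compound 4 is 5 h, with a range of 1.5 h to 15 h.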

Compound 4, half-life: 0.267 h
Compound 4: the middle estimate sits 19-fold (1.27 log units) above what was measured; measured number outside the range, below it.
By their numbers in this assay, from the lowest: compound 4; then compound 2; then compound 1; then compound 3.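

In this assay, the isopropyl(methyl)carbamoyl group on the saturated chain carbon bound to an oxygen next to a carbonyl group gives the lowest number of the series, below all three earlier ester groups (a 62-fold lower number from compound 3 to compound 4 (1.79 log units; beyond the scatter); a 5.3-fold lower number from compound 2 to compound 4 (0.73 log units; beyond the scatter); a 30-fold lower number from compound 1 to compound 4 (1.47 log units; beyond the scatter)). The position therefore reaches lower than isopropyl had shown, and the carbamoyl group does not carry the read-out towards that of the other ring-free group, the one in compound 1, so the absence of a ring does not by itself set the number. No measurement here accounts for the fall.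

Open, as far as these compounds go, is whether the low number follows the carbamoyl group as such or the isopropyl on its nitrogen. A dimethylcarbamoyl or morpholine amide on the same carbon would separate these, and a benzyloxymethyl group would test how far the ether-linked phenyl ring can be moved.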